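Swapping an aryl amine arm for a piperidinylpropyl chain

The source may hold more compounds than are shown below. What is called first, only, known or untested is meant among the compounds shown, and "the series" means these compounds.

Compound 1, `CCN(Cc1ccc(Br)cc1)c1ccc(C(=O)N2CCc3ccc(OS(N)(=O)=O)cc3C2)cc1`, is the stronger of the two measured compounds: in an assay on HEK293 cells for inhibition of Steryl-sulfatase (Homo sapiens), tested at 0.1 uM (on this read-out higher numbers stand for a stronger effect at the one concentration tested and lower numbers for a weaker effect), compound 1 gives 78.2%, while compound 2, `NS(=O)(=O)Oc1ccc2c(c1)CN(C(=O)c1cccc(N(CCCO)Cc3ccccc3)c1)CC2`, gives 25.8%, a gap beyond the scatter. Compound 3, `CN(CCCN1CCCCC1)c1ccc(C(=O)N2CCc3ccc(OS(N)(=O)=O)cc3C2)cc1`, has not yet been measured. It differs from compound 1 in one place: methyl(3-(piperidin-1-yl)propyl)amino in place of (4-bromobenzyl)(ethyl)amino on an aromatic carbon. With no comparable change among the measured pairs, the expected step of a number 23.2 percentage points lower from compound 1 to compound 3 (beyond the scatter) is a moderate drop, because compound 1 gives 78.2% while compound 2 gives 25.8%, a gap beyond the scatter that shows how far a change on this part of the core can reach. Compound 3 is estimated at 55%, within 30% to 80%.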

Compound 3, a percentage reported as inhibition, at one concentration (the size of the read-out at that concentration, not a potency): 17.4%
For compound 3 the middle estimate is 37.6 percentage points above the measured one, outside the stated range (below it).
By their numbers in this assay, from the lowest: compounds 3 and 2 (each within the scatter of the next); then compound 1.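

In this assay, among these compounds, putting methyl(3-(piperidin-1-yl)propyl)amino in place of (4-bromobenzyl)(ethyl)amino gives a number 60.8 percentage points lower from compound 1 to compound 3 (beyond the scatter) and is the first change in one place to show that this aromatic carbon tolerates not every arm. The two groups match in heavy-atom count, yet they differ in ring type and in bromine against a second nitrogen. Nothing measured here identifies which difference accounts for the step. As far as these compounds go, it remains open whether a 4-chlorobenzyl arm would keep the higher number, or whether a morpholine in place of the piperidine would change the lower one.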